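Phenyl to vinyl in a weakly active series

The source may report more compounds than this note shows. Statements on the series, on what has been measured and on what is new or still open speak of the compounds shown alone.

In a functional assay on KB cells (Homo sapiens) for cytotoxicity (on this read-out lower numbers stand for stronger inhibition and higher numbers for weaker inhibition), compound 1 (`C=CCn1cc(C#N)c2c(N)ncnc21`) reads > 100000 nM as a limit and not a number. Within the data shown here, compound 2 (`NC(=S)c1cn(Cc2ccccc2)c2ncnc(N)c12`) reads 32000 nM and so holds the only true number so far. The next entry is compound 3 (`C=CCn1cc(C(N)=S)c2c(N)ncnc21`), which carries vinyl in place of phenyl on a saturated chain carbon bound to an aromatic nitrogen. Among the measured compounds shown here, no measured step in this assay gauges this change, so the size of the move remains an expectation, with compound 2 at 32000 nM as the sole anchor. A modest shift towards weaker inhibition is expected, perhaps not far beyond the scatter. The estimated move is a 1.7-fold higher number from compound 2 to compound 3 (0.24 log units; within the scatter) on this read-out. For compound 3 the estimate is 55000 nM with an expected range of 18000 nM to 150000 nM in this assay.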

Compound 3, half-maximal inhibitory concentration: 19000 nM
Estimate against measurement, compound 3: 2.9-fold (0.46 log units) above, and the stated range covers the measured number.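

In this assay, the position on a saturated chain carbon bound to an aromatic nitrogen now has its first measured step, a 1.7-fold lower number from compound 2 to compound 3 (0.23 log units; within the scatter), so this read-out does not separate vinyl from phenyl there, and the ring is not required for the activity seen so far. Among these compounds, the change on an aromatic carbon gives an at least 5.2-fold lower number from compound 1 to compound 3 (0.72 log units; beyond the scatter), the only step that lies beyond the scatter. Compound 1 stands at a limit, so this step gives a lower bound and not a size: the limit of > 100000 nM in this assay, at which 1 of the 3 values shown sits.

On these data alone, whether sulfur itself matters remains open, and a carboxamide or an amine on that aromatic carbon would test this. A propyl chain in place of vinyl would show whether the double bond counts at the chain position.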